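The source may hold more compounds than are shown below. What is called first, only, known or untested is meant among the compounds shown, and "the series" means these compounds.

In an ADME assay on HepG2 cells (Homo sapiens) for cytotoxicity, read by MTT assay, with a stated time of 72 h (on this read-out higher numbers stand for lower toxicity in this test and lower numbers for higher toxicity in this test), two compounds sharing one core have been measured, and neither gives a plain number. Compound 2 `Cc1nc2c(Br)cc(Cl)cn2c1[N+](=O)[O-]` stands at > 125000 nM, which is a limit of the assay and not a number. Compound 1 `CSCc1nc2c(Br)cc(Cl)cn2c1[N+](=O)[O-]` stands at > 15600 nM, which is also a limit.

Compound 3 `C[S+]([O-])Cc1nc2c(Br)cc(Cl)cn2c1[N+](=O)[O-]` differs from compound 2 by one change: a group of 3 heavy atoms (1 carbon, 1 oxygen, 1 sulfur; no ring) in place of a hydrogen atom, on a saturated chain carbon bound to an aromatic carbon. Among the compounds with values here, the one measured step that bears on this change is a step that the two limits leave unreadable from compound 1 to compound 2. It also concerns a group on a saturated chain carbon bound to an aromatic carbon, but it offers no size or firm direction to carry over.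

The closest guide is therefore compound 1, which also has a group at that place and whose only reading is the limit of > 15600 nM. In this assay, compound 3 is expected to show low toxicity, quite possibly reported only as a limit, and any fall from compound 2 is tentative. The expected step is an at least 2.0-fold lower number from compound 2 to compound 3 (0.31 log units; beyond the scatter). The estimated value for compound 3 is 60000 nM, with an expected range from 15000 nM to 200000 nM.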

Compound 3, half-maximal cytotoxic concentration: 51400 nM
Compound 3: middle estimate off by 1.2-fold (0.07 log units), on the high side; the range from low to high includes it.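

In this assay, within the data shown here, compound 3 gives the only plain number among the three compounds, so a group at this place finally has a measurable consequence. Putting the group of 3 heavy atoms in place of a hydrogen atom, on a saturated chain carbon bound to an aromatic carbon, gives an at least 2.4-fold lower number from compound 2 to compound 3 (0.38 log units; beyond the scatter), which means higher toxicity in this test. The true size of that step may be larger, and only its smallest size can be stated because the reading for compound 2 is a limit of the assay and not a number: the limit of > 125000 nM in this assay, at which 1 of the 3 values shown sits.

The steps that involve compound 1 cannot be read, so the groups of compound 1 and compound 3 cannot be placed in order of toxicity. Going by these compounds, it remains open whether the lower number belongs to this particular sulfur- and oxygen-bearing group or would also come with other groups at this place, such as an amine, a carboxylic acid or a longer chain, and whether the step would carry over to a different core.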